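The source may hold more compounds than are shown below. What is called first, only, known or untested is meant among the compounds shown, and "the series" means these compounds.

In a functional assay on MCF7 cells (Homo sapiens) for antiproliferative activity, read by MTT assay, with a stated time of 48 h (on this read-out higher numbers stand for weaker inhibition and lower numbers for stronger inhibition), compound 1 `CC(C)=CCC[C@]1(C)/C=C/[C@@H](OC(=O)C=C(C)C)[C@](C)(O)/C=C/C(=O)/C(C(=O)O)=C\C1` gives 16100 nM, and compound 2 `COCOC/C1=C/C[C@](C)(CCC=C(C)C)/C=C/[C@@H](OC(=O)C=C(C)C)[C@](C)(O)/C=C/C1=O` gives 3120 nM, the lower of the two numbers. Compound 3 `CC(C)=CCC[C@]1(C)/C=C/[C@@H](OC(=O)C=C(C)C)[C@](C)(O)/C=C/C(=O)/C(C(=O)N2CCCC2)=C\C1` follows from compound 2 by (pyrrolidin-1-yl)carbonyl in place of (methoxymethoxy)methyl on a double-bonded ring carbon. Going by the values given here, only one measured step bears on this change: the modest 5.2-fold lower number from compound 1 to compound 2 (0.71 log units; beyond the scatter), beyond the scatter. Compound 3 shares a carbonyl on that double-bonded ring carbon with compound 1, which stands at 16100 nM, so a modest move to a higher number is expected in this assay. The expected change is a 2.1-fold higher number from compound 2 to compound 3 (0.32 log units; beyond the scatter). Compound 3 is estimated at 6500 nM, with a range of 2200 nM to 20000 nM.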

Compound 3, half-maximal inhibitory concentration: 17200 nM
Compound 3: the middle estimate sits 2.6-fold (0.42 log units) below what was measured, and the stated range covers the measured number.
By their numbers in this assay, from the lowest: compound 2; then compounds 1 and 3 (each within the scatter of the next).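

In this assay the step of a 5.5-fold higher number from compound 2 to compound 3 (0.74 log units; beyond the scatter) shows that (pyrrolidin-1-yl)carbonyl on this double-bonded ring carbon does not keep the lower number seen with (methoxymethoxy)methyl. With pyrrolidin-1-yl in place of hydroxy on the carbonyl carbon, a 1.1-fold higher number from compound 1 to compound 3 (0.03 log units; within the scatter), the carboxylic acid and the amide read alike. No measurement here accounts for this. As far as these compounds go, whether the lower number belongs to the ether side chain itself or to the lack of a carbonyl on this carbon stays open; a hydroxymethyl or plain methyl group there would separate the two.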